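Urea to Thiourea with a Pyridine Ring: Expected Potency

The source may hold more compounds than are shown below. What is called first, only, known or untested is meant among the compounds shown, and "the series" means these compounds.

Compound 1 `NC(=O)c1c(NC(=O)c2ccccc2Cl)sc2c1CCN(C(=S)Nc1ccccc1)C2`: 15600 nM
Compound 2 `NC(=O)c1c(NC(=O)c2ccccc2Cl)sc2c1CCN(C(=S)Nc1c(Cl)cccc1Cl)C2`: 4020 nM
Compound 3 `NC(=O)c1c(NC(=O)c2ccccc2Cl)sc2c1CCN(C(=O)Nc1c(Cl)cccc1Cl)C2`: 24400 nM

Three compounds share one core and differ only in the group on the amine nitrogen in a ring. In a functional assay on MKN-74 cells (Homo sapiens) for antiproliferative activity, with a stated time of 24 h (a higher number here means a weaker inhibitor, a lower number a stronger inhibitor), compound 3 gives 24400 nM, the highest of the three numbers; it sits within the scatter of compound 1 and well apart from compound 2, as a 6.1-fold higher number from compound 2 to compound 3 (0.78 log units; beyond the scatter) shows.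

Compound 4 `NC(=O)c1c(NC(=O)c2ccccc2Cl)sc2c1CCN(C(=S)Nc1cccnc1)C2` has not been measured. The change from compound 3 is a group of 9 heavy atoms (6 carbon, 2 nitrogen, 1 sulfur; one six-membered aromatic ring with 1 hetero atom) in place of a group of 11 heavy atoms (7 carbon, 1 nitrogen, 1 oxygen, 2 chlorine; one six-membered aromatic ring of carbon only), on an amine nitrogen in a ring. Among the measured compounds shown here, two measured steps bear on it. The step of a 6.1-fold higher number from compound 2 to compound 3 (0.78 log units; beyond the scatter) shows that exchanging a thiocarbonyl for a carbonyl raised the number; compound 4 reverses that exchange, which should lower it. The step of a 3.9-fold lower number from compound 1 to compound 2 (0.59 log units; beyond the scatter) shows that two chlorines on the aromatic ring lowered the number; compound 4 lacks them, which should raise it. These two pulls roughly cancel, leaving compound 4 most like compound 1, whose ring carries no chlorines and no hetero atom.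

Compound 4 is therefore expected to give 15000 nM, with a range of 5000 nM to 40000 nM. The expected step of a 1.6-fold lower number from compound 3 to compound 4 (0.21 log units; within the scatter) is not beyond the scatter.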

Compound 4, half-maximal inhibitory concentration: 38600 nM
The estimate for compound 4 lay 2.6-fold (0.41 log units) below the measured number; the range from low to high includes it.
By their numbers in this assay, from the lowest: compound 2; then compounds 1, 3 and 4 (each within the scatter of the next, the first and the last beyond it).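

In this assay, placing pyridin-3-yl on the amide-type nitrogen in place of phenyl gives a 2.5-fold higher number from compound 1 to compound 4 (0.39 log units; beyond the scatter), which shows that a ring nitrogen in this aromatic ring alone can shift the number, and here it shifts it upward. Exchanging 2,6-dichlorophenyl for pyridin-3-yl gives the larger 9.6-fold higher number from compound 2 to compound 4 (0.98 log units; beyond the scatter), so among the three compounds with a thiocarbonyl and one differing ring, 2,6-dichlorophenyl gives the lowest number, phenyl the next and pyridin-3-yl the highest. The remaining comparison, a 1.6-fold higher number from compound 3 to compound 4 (0.20 log units; within the scatter), stays within the scatter, so a thiocarbonyl compound does not always give a lower number than a carbonyl compound: compound 4 has the thiocarbonyl and does not differ measurably from compound 3 , which has the carbonyl.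

Nothing available here says why the pyridin-3-yl ring behaves this way. Also open, on these data alone, are how a single chlorine, a methoxy group or an amine on the phenyl ring would compare, and what the carbonyl form carrying pyridin-3-yl would give, a number that would separate the effect of the ring from that of the carbonyl.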